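Aryl exchange from compound 2 to compound 3

A few compounds are considered here, and "the series" means these few. Any claim that something is new, unique, unknown or untested is made for them only; others in the source may bear on it.

Values in a functional assay on CCRF-CEM cells (Homo sapiens) for inhibition, read by MTT assay, with a stated time of 72 h (on this read-out lower numbers stand for stronger inhibition and higher numbers for weaker inhibition), so far
compound 1 `COc1cc(NC(C)CCCNC(=O)Nc2ccc(Br)cc2)c2ncccc2c1` gives 23000 nM
compound 2 `COc1cc(NC(C)CCCNC(=O)Nc2cccc(O)c2)c2ncccc2c1` gives 32000 nM

Compound 2 stands within the scatter of compound 1, and no order can be drawn between them. Going by the values given here, compound 3 `COc1cc(NC(C)CCCNC(=O)Nc2ccc(C(F)(F)F)cc2)c2ncccc2c1` has 4-(trifluoromethyl)phenyl in place of 3-hydroxyphenyl on an amide-type nitrogen as its only change. Among the compounds with values here, the one measured exchange at this nitrogen gave a 1.4-fold higher number from compound 1 to compound 2 (0.14 log units; within the scatter) and so no step beyond the scatter is expected in this assay in either direction. The expected step is a 1.5-fold lower number from compound 2 to compound 3 (0.16 log units; within the scatter) on this reading. Compound 3 is estimated at 22000 nM with an expected range from 10000 nM to 48000 nM pending measurement.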

Compound 3, half-maximal inhibitory concentration: 14000 nM
Compound 3: middle estimate off by 1.6-fold (0.20 log units), on the high side; measured number inside the range.
By their numbers in this assay, from the lowest: compounds 3, 1 and 2 (each within the scatter of the next, the first and the last beyond it).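

In this assay, going by these compounds alone, the exchange on the amide-type nitrogen gives a 2.3-fold lower number from compound 2 to compound 3 (0.36 log units; beyond the scatter) and thus the first step beyond the scatter, though a modest one, with 4-(trifluoromethyl)phenyl in place of 3-hydroxyphenyl. Trifluoromethyl in place of bromo on an aromatic carbon gives a 1.6-fold lower number from compound 1 to compound 3 (0.22 log units; within the scatter) and so does not separate these two groups. Nothing on hand accounts for either step. The compounds shown do not separate the hydroxy group from its place on the ring. As far as these compounds go, what an amine or a carboxylic acid on that phenyl ring would give remains open.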